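Extending the oxane-bearing side chain in a kinase inhibitor series

The source may hold more compounds than are shown below. What is called first, only, known or untested is meant among the compounds shown, and "the series" means these compounds.

Measured compounds:
compound 1 `N#Cc1cnc(NCc2cnccc2C(F)(F)F)cc1N[C@H]1CC[C@@H](O)CC1` — 100 nM
compound 2 `N#Cc1cnc(NCc2cnccc2C(F)(F)F)cc1NC1CCOCC1` — 900 nM

In an assay on isolated protein for inhibition of protein kinase C theta type (Homo sapiens), read by TR-FRET, with a stated time of 2 h (a lower number here means a stronger inhibitor, a higher number a weaker inhibitor), compound 2 stands highest of the two numbers; its nearest neighbour is compound 1, at 100 nM. Compound 3 `N#Cc1cnc(NCc2cnccc2C(F)(F)F)cc1NCCC1CCOCC1` differs from compound 2 by 2-(oxan-4-yl)ethyl in place of oxan-4-yl on a nitrogen on an aromatic ring. Within the data shown here, the only measured step, a 9.0-fold higher number from compound 1 to compound 2 (0.95 log units; beyond the scatter), concerns exchange of the ring itself, not insertion of a chain between ring and nitrogen, so it bears on this change only loosely. A modest step upward in this assay is therefore expected, namely a 2.8-fold higher number from compound 2 to compound 3 (0.44 log units; beyond the scatter). Compound 3 is expected to give about 2500 nM, most likely between 600 nM and 10000 nM.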

Compound 3, half-maximal inhibitory concentration: 1200 nM
Compound 3: middle estimate off by 2.1-fold (0.32 log units), on the high side, within the range that was stated.
By their numbers in this assay, from the lowest: compound 1; then compounds 2 and 3 (each within the scatter of the next).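

In this assay, placing the oxane ring on a 2-(oxan-4-yl)ethyl chain rather than directly on the nitrogen leaves compound 2 and compound 3 within the scatter of each other (a 1.3-fold higher number from compound 2 to compound 3 (0.12 log units; within the scatter)). At this position, the chain therefore does not separate the two oxane-bearing compounds, and the gap to the 4-hydroxycyclohexyl group remains beyond the scatter (a 12-fold higher number from compound 1 to compound 3 (1.08 log units; beyond the scatter)). No available evidence explains either step. Still open, from the compounds shown here alone, is whether a 2-(4-hydroxycyclohexyl)ethyl group, or an amine or carboxylic acid at the end of a longer chain, would come closer to compound 1.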